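Para substituent on the benzyl ring: methoxy next

The compounds below may be only part of what the source reports. "The series", "measured", "known", "first", "only" and "open" are said of these compounds alone.

Compound 3 `O=C(NCc1cn(Cc2ccc(C(F)(F)F)cc2)nn1)c1cn(-c2ccccc2)nc1-c1ccc(F)cc1` gives 810 nM in a functional assay on MCF7 cells (Homo sapiens) for antiproliferative activity, read by sulforhodamine B assay, with a stated time of 48 h (a lower number here means a stronger inhibitor of growth, a higher number a weaker inhibitor of growth), the second highest of the three numbers recorded so far. Its nearest neighbour is compound 2 `O=C(NCc1cn(Cc2ccc(Cl)cc2)nn1)c1cn(-c2ccccc2)nc1-c1ccc(F)cc1` with 130 nM, the step being a 6.2-fold higher number from compound 2 to compound 3 (0.79 log units; beyond the scatter); its furthest is compound 1 `O=C(NCc1cn(Cc2ccc(F)cc2)nn1)c1cn(-c2ccccc2)nc1-c1ccc(F)cc1` with 55300 nM, the step being a 68-fold lower number from compound 1 to compound 3 (1.83 log units; beyond the scatter). The whole spread of the series comes from one position, as a 430-fold lower number from compound 1 to compound 2 (2.63 log units; beyond the scatter) also shows.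

Compound 4 `COc1ccc(Cn2cc(CNC(=O)c3cn(-c4ccccc4)nc3-c3ccc(F)cc3)nn2)cc1` changes the same position again: methoxy in place of trifluoromethyl on an aromatic carbon. All three measured steps bear on it, since each swaps the group on that ring, and two of the three were large, while none of them introduces methoxy, so the direction is open. Going by the values given here, a step beyond the scatter in either direction is considered likely, with a weaker result somewhat favoured because the only group that fell far off the others gave compound 1 its 55300 nM.

Compound 4 is therefore expected at 2500 nM, within 250 nM to 30000 nM, an estimated step of a 3.1-fold higher number from compound 3 to compound 4 (0.49 log units; beyond the scatter).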

Compound 4, concentration for 50% growth inhibition: 650 nM
The estimate for compound 4 lay 3.8-fold (0.59 log units) above the measured number; measured number inside the range.
By their numbers in this assay, from the lowest: compound 2; then compounds 4 and 3 (each within the scatter of the next); then compound 1.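

In this assay, methoxy and trifluoromethyl cannot be told apart at this position, with a 1.2-fold lower number from compound 3 to compound 4 (0.10 log units; within the scatter), so two groups that share neither atoms nor hydrogen-bond acceptor count give the same read-out. Going by these compounds alone, compound 2 remains the strongest of the four, with a 5.0-fold higher number from compound 2 to compound 4 (0.70 log units; beyond the scatter), and compound 1 the weakest, with an 85-fold lower number from compound 1 to compound 4 (1.93 log units; beyond the scatter), which leaves fluoro as the one group far from the others and chloro as the only group clearly ahead of the pair. No measurement shown here explains any of these differences.

Open, from the compounds shown here alone, is whether bromo, a methyl group or a dimethylamino group at this position would fall with compound 2, with compounds 3 and 4, or nearer compound 1. Also open, going by these compounds, is whether this order holds on a changed core.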